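Hydroxy-to-amino on the carbonyl carbon: a repeated change

The compounds below may be only part of what the source reports. "The series", "measured", "known", "first", "only" and "open" are said of these compounds alone.

Compound 1 `C=C1C[C@@H]1CC(=O)O` gives 60000 nM in a functional assay (Hepatocyte) for inhibition, with Rattus norvegicus as the target; on this read-out higher numbers stand for weaker inhibition and lower numbers for stronger inhibition. Compound 2 `C=C1C[C@@H]1CC(N)=O` gives 30000 nM in this assay. Between them is amino in place of hydroxy on a carbonyl carbon, and that change made a 2.0-fold lower number from compound 1 to compound 2 (0.30 log units; within the scatter). Compound 3 `C=C1[C@@H](CC(=O)O)[C@H]1CCCCCCCCCCCC` gives 25000 nM in this assay. The difference between the core of compound 1 and the core of compound 3 is not broken down here. Compound 4 `C=C1[C@@H](CC(N)=O)[C@H]1CCCCCCCCCCCC` is not yet measured in this assay. It differs from compound 3 by amino in place of hydroxy on a carbonyl carbon, the same change as from compound 1 to compound 2, at the same kind of place. For the measured compounds named here, with that earlier step as the only guide, a change of about the same size is expected from compound 3 to compound 4, namely a 1.8-fold lower number from compound 3 to compound 4 (0.25 log units; within the scatter), resting on a 2.0-fold lower number from compound 1 to compound 2 (0.30 log units; within the scatter). Compound 4 is therefore estimated at 14000 nM, between 5000 nM and 40000 nM.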

Compound 4, half-maximal inhibitory concentration: 32000 nM
Compound 4: middle estimate off by 2.3-fold (0.36 log units), on the low side; measured number inside the range.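

In this assay, amino in place of hydroxy on a carbonyl carbon made a 1.3-fold higher number from compound 3 to compound 4 (0.11 log units; within the scatter). Set beside the earlier step, the two do not differ beyond what repeated measurement allows: the same change on two cores in this assay, a 2.0-fold lower number (0.30 log units; within the scatter) from compound 1 to compound 2 and a 1.3-fold higher number (0.11 log units; within the scatter) from compound 3 to compound 4, 2.6-fold (0.41 log units) apart, within the scatter of two such steps. This gives no sign that the core of compound 1 and the core of compound 3 respond differently to the change, but with both steps inside the scatter it does not show that the change has any effect on either core, nor does it fix a size or direction to carry over.

The compounds shown leave open whether a methyl ester or a hydroxamic acid on the carbonyl carbon would move the number beyond the scatter on either core. They also leave open whether a shorter alkyl chain in place of the long chain of compound 3 and compound 4 would alter the outcome of this change.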